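The source may report more compounds than this note shows. Statements on the series, on what has been measured and on what is new or still open speak of the compounds shown alone.

Compound 2 `Cc1ccccc1-c1ccc(-c2nnc(N(C)Cc3ccc4nccn4c3)o2)cc1` is measured in an assay on isolated protein for inhibition of tyrosine-protein kinase Mer (Homo sapiens), read by LC-MS (on this read-out lower numbers stand for stronger inhibition and higher numbers for weaker inhibition), and gives 12.6 nM. Among the two compounds measured so far it has the lowest number; compound 1 `CN(Cc1ccc2nccn2c1)c1nnc(-c2ccc(-c3ccccc3)cc2)o1` gives 39.8 nM, and the gap between them, a 3.2-fold lower number from compound 1 to compound 2 (0.50 log units; beyond the scatter), arises from a single methyl set in place of a hydrogen on an aromatic carbon. Compound 3 `Cc1nn(C)c(C)c1-c1ccc(-c2nnc(N(C)Cc3ccc4nccn4c3)o2)cc1` has not yet been measured. It differs from compound 2 in one place only: 1,3,5-trimethyl-1H-pyrazol-4-yl in place of 2-methylphenyl on an aromatic carbon. The six-membered aromatic ring of carbon only is thus exchanged for a five-membered aromatic ring with 2 hetero atoms that bears methyls. No measured step bears directly on such an exchange; the one step shown, a 3.2-fold lower number from compound 1 to compound 2 (0.50 log units; beyond the scatter), concerns only a methyl added to the very ring that now disappears, so it offers little guidance about replacing the ring as a whole. The expectation is therefore wide. A modest move toward a higher number is expected, a 2.4-fold higher number from compound 2 to compound 3 (0.38 log units; beyond the scatter). For compound 3 the estimate in this assay is 30 nM, with a range from 8 nM to 120 nM.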

Compound 3, half-maximal inhibitory concentration: 31.6 nM
Beside the measured number, compound 3's estimate is 1.1-fold (0.02 log units) below it; the range from low to high includes it.
By their numbers in this assay, from the lowest: compound 2; then compounds 3 and 1 (each within the scatter of the next).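

In this assay, replacing the 2-methylphenyl of compound 2 with 1,3,5-trimethyl-1H-pyrazol-4-yl gives a 2.5-fold higher number from compound 2 to compound 3 (0.40 log units; beyond the scatter) and so moves the number beyond the scatter, which shows that this place, on an aromatic carbon para to a large group, responds to an exchange of the whole ring and not only to the single methyl seen earlier. Against the plain phenyl, the same exchange gives a 1.3-fold lower number from compound 1 to compound 3 (0.10 log units; within the scatter) and leaves the two compounds indistinguishable, so among these three compounds only the 2-methylphenyl stands clearly apart, and a five-membered aromatic ring with 2 hetero atoms can take the place of a phenyl without a measurable difference. No accompanying measurement speaks to the reason behind these numbers.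

The compounds shown leave open how a pyrazole ring without its methyls, or a pyridine ring, would read at this place. From the compounds shown here alone, it also remains open whether a chlorine or a methoxy group in place of the methyl of compound 2 would keep its lower number.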